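Urea in place of amide on the sulfonate ester series

The source may report more compounds than this note shows. Statements on the series, on what has been measured and on what is new or still open speak of the compounds shown alone.

Compound 2 `CCCC(=O)Nc1ccc(S(=O)(=O)Oc2ccccc2C(C)C)cc1` gives the lowest of the three numbers in a functional assay on HT-1080 cells (Homo sapiens) for antiproliferative activity, read by sulforhodamine B assay, with a stated time of 48 h (a higher number here means a weaker inhibitor, a lower number a stronger inhibitor), with 950 nM. Compound 3 `CCCC(=O)Nc1ccc(S(=O)(=O)Oc2ccccc2I)cc1` gives 2000 nM, and compound 1 `CCC(=O)Nc1cccc(S(=O)(=O)Oc2ccccc2C(C)C)c1` gives 12000 nM. Within the data shown here, the only single-change step known here is a 2.1-fold higher number from compound 2 to compound 3 (0.32 log units; beyond the scatter), which is not a change at the amide end. Compound 4 `CC(C)c1ccccc1OS(=O)(=O)c1ccc(NC(=O)NCCCCl)cc1` differs from compound 2 by (3-chloropropyl)amino in place of propyl on a carbonyl carbon. Among the measured compounds shown here, no measured pair shows the effect of this change, so the expectation rests on the small spread of the known numbers around compound 2. A modest step is expected, a 1.6-fold higher number from compound 2 to compound 4 (0.20 log units; within the scatter), with little confidence in its direction. Compound 4 is therefore estimated at 1500 nM, between 500 nM and 4500 nM.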

Compound 4, half-maximal inhibitory concentration: 2700 nM
Compound 4: middle estimate off by 1.8-fold (0.26 log units), on the low side; low and high end bracket the measured number.
By their numbers in this assay, from the lowest: compound 2; then compounds 3 and 4 (each within the scatter of the next); then compound 1.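

Putting (3-chloropropyl)amino in place of propyl on the carbonyl carbon turns the amide into a urea and gives a 2.8-fold higher number from compound 2 to compound 4 (0.45 log units; beyond the scatter) in this assay. Among these compounds, this is the first step measured at this end of the molecule, and it shows that the position accepts the urea with its chlorinated chain at a modest cost. Nothing available explains the rise.

From the compounds shown here alone, whether it follows from the added nitrogen or from the chlorine stays open, and a urea carrying plain propyl would separate the two. Going by these compounds, the effect of chain length is also open, as a 2-chloroethyl group on the same urea nitrogen would show.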